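Extending the ester on the shared core

A few compounds are considered here, and "the series" means these few. Any claim that something is new, unique, unknown or untested is made for them only; others in the source may bear on it.

Compound 1 `CCOC(=O)c1ccc(-c2nn(C)c3ccccc23)cc1` is the parent of the series. In a functional assay on cells (Platelet, Homo sapiens) for inhibition (a lower number here means a stronger inhibitor, a higher number a weaker inhibitor), compound 1 reaches only the limit > 10000 nM. Compound 2 `CCOC(=O)c1ccc(-c2nn(Cc3ccncc3)c3ccccc23)cc1` carries pyridin-4-yl in place of hydrogen on a saturated chain carbon bound to an aromatic nitrogen. In this assay compound 2 likewise gives the limit > 10000 nM. The step that the two limits leave unreadable from compound 1 to compound 2 therefore cannot be read. Compound 3 `COC(=O)c1ccc(-c2nn(Cc3ccccc3)c3ccccc23)cc1` stands no differently: in this assay compound 3 gives > 10000 nM. The whole set is summarised by the limit of > 10000 nM in this assay, at which 3 of the 3 values shown sit. Compound 4 `CCOC(=O)/C=C/c1ccc(-c2nn(Cc3ccccc3)c3ccccc23)cc1` differs from compound 3 by 2-(ethoxycarbonyl)ethenyl in place of methoxycarbonyl on an aromatic carbon. For the measured compounds named here, no measured step bears on this change, and every value so far is a limit, so the series gives no size to anticipate. Compound 4 is expected in this assay at 15000 nM, with a range from 4000 nM to 60000 nM. The expected step that the limit leaves unreadable from compound 3 to compound 4 is counted from a limit and stays tentative.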

Compound 4, half-maximal inhibitory concentration: > 10000 nM
Compound 4: a limit, no number (the forecaster's own chance of this, stated with the estimate: 75%); the middle value lies beyond the limit too.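

Compound 3 and compound 4 both give only limits in this assay, so the step between them cannot be read. The compounds shown leave open which change on the shared core, if any, gives a measurable inhibition value, with the series so far resting at a single limit: the limit of > 10000 nM in this assay, at which 4 of the 4 values shown sit.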